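Swapping a Chlorinated Ring for Pyridine in Compound 4

The source may report more compounds than this note shows. Statements on the series, on what has been measured and on what is new or still open speak of the compounds shown alone.

Three compounds have been measured in a functional assay on ileum for antagonist activity at histamine H1 receptor (Cavia porcellus); on this read-out higher numbers stand for weaker binding and lower numbers for tighter binding:

compound 1 `N=C(NCCCc1c[nH]cn1)NCCCC(c1ccccc1)c1ccccn1` gives 251 nM
compound 2 `N=C(NCCCc1c[nH]cn1)NCCCC(c1ccc(F)cc1)c1ccccn1` gives 46.8 nM
compound 3 `N=C(NCCCc1c[nH]cn1)NCCC(c1ccc(Cl)cc1)c1ccccn1` gives 77.6 nM

Compound 3 stands second highest of the three numbers; its gap to compound 2 lies within the scatter, while compound 1 sits beyond the scatter above it. Compound 4 `N=C(NCCCc1c[nH]cn1)NCCC(c1ccccn1)c1ccccn1` differs from compound 3 by pyridin-2-yl in place of 4-chlorophenyl on a saturated chain carbon bound to an aromatic carbon and a saturated chain carbon. Among the measured compounds shown here, the only measured step, a 5.4-fold lower number from compound 1 to compound 2 (0.73 log units; beyond the scatter), concerns a different change and does not bear directly on this one. For the measured compounds named here, with no guiding step, a change of modest size in either direction, or none beyond the scatter, is expected, so compound 4 is estimated at 120 nM, ranging from 30 nM to 500 nM, which means an expected step of a 1.5-fold higher number from compound 3 to compound 4 (0.19 log units; within the scatter).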

Compound 4, dissociation constant: 389 nM
Beside the measured number, compound 4's estimate is 3.2-fold (0.51 log units) below it; the measured number falls inside the stated range.
By their numbers in this assay, from the lowest: compounds 2 and 3 (each within the scatter of the next); then compounds 1 and 4 (each within the scatter of the next).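

In this assay the group on this saturated chain carbon clearly matters: pyridin-2-yl in place of 4-chlorophenyl brings a 5.0-fold higher number from compound 3 to compound 4 (0.70 log units; beyond the scatter) and so weaker binding. The earlier step changed only a hydrogen on an aromatic carbon, whereas this one replaces a whole ring, showing that the ring itself can shift the read-out. Nothing available explains why this swap weakens binding. Going by these compounds, whether a pyridin-3-yl or a 4-methoxyphenyl group at this place would fall nearer compound 3 or compound 4 stays open.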